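From Propoxy to Acetyl on a Fused Aromatic Ring

A few compounds are considered here, and "the series" means these few. Any claim that something is new, unique, unknown or untested is made for them only; others in the source may bear on it.

Compound 2 `CCCOc1ccc2ccc(=O)oc2c1CCC(C)C` carries a propoxy group on an aromatic carbon of its fused core. For the measured compounds named here, in a functional assay on V79 cells (Cricetulus griseus) for cytotoxicity (on this read-out lower numbers stand for stronger inhibition and higher numbers for weaker inhibition), compound 2 gives 5600 nM, and this is the only proper number among the values shown. Compound 1 `COc1ccc2c(c1CCC(C)C)OC(=O)CC2`, built on a different core, reached only a limit of this assay, and for compound 1 that limit is > 100000 nM, which is the limit of > 100000 nM in this assay, at which 1 of the 2 values shown sits. Compound 3 `CC(=O)c1ccc2ccc(=O)oc2c1CCC(C)C` is the next structure, not yet measured, and it differs from compound 2 by acetyl in place of propoxy on an aromatic carbon. Going by the values given here, no pair of measured compounds separated by one change exists here, so the size of such a step cannot be read from data. The step of a 2.7-fold higher number from compound 2 to compound 3 (0.43 log units; beyond the scatter) is expected to weaken inhibition beyond the usual scatter. Compound 3 is therefore estimated at 15000 nM, with a range from 3000 nM to 80000 nM.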

Compound 3, half-maximal inhibitory concentration: 60000 nM
The estimate for compound 3 lay 4.0-fold (0.60 log units) below the measured number; the measured number falls inside the stated range.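

In this assay, putting acetyl in place of propoxy on this aromatic carbon, ortho to an isopentyl group, gives an 11-fold higher number from compound 2 to compound 3 (1.03 log units; beyond the scatter), so inhibition weakens clearly. This shows that the position is sensitive to what it carries: neither group has a ring or a net charge, and both have the same hydrogen-bond acceptor count, yet the read-out still moves well beyond the scatter. Compound 3 still gives a proper number rather than a limit, so this step can be read in full: the limit of > 100000 nM in this assay, at which 1 of the 3 values shown sits.

A single step cannot show which difference between the two groups matters, whether the double bond of the acetyl group or the ether oxygen and chain of the propoxy group. From the compounds shown here alone, how an amine, a hydroxyl or a longer alkoxy chain such as butoxy would behave at this position remains open.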